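The source may hold more compounds than are shown below. What is called first, only, known or untested is meant among the compounds shown, and "the series" means these compounds.

Compound 2, `O=C([C@H]1C[C@H]1F)N1CC2CC(C1)N2`, carries a 2-fluorocyclopropyl group on the carbonyl carbon of the shared core. Among the measured compounds shown here, in an assay on SH-EP1 cells for agonist activity at Neuronal acetylcholine receptor; alpha4/beta2 (Homo sapiens), read by FLIPR and calcium flux (on this read-out higher numbers stand for larger maximal responses and lower numbers for smaller maximal responses), compound 2 gives 110%, the highest of the two numbers measured so far. Its nearest neighbour is compound 1, `CC(=O)N1CC2CC(C1)N2`, which bears a methyl on the same carbonyl carbon; in this assay compound 1 gives 94%. For the measured compounds named here, the single measured step, a number 16 percentage points higher from compound 1 to compound 2 (beyond the scatter), is modest but beyond the scatter.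

Compound 3, `O=C([C@@H]1C[C@@H]1F)N1CC2CC(C1)N2`, differs from compound 2 in this way: the two compounds have the same atoms and bonds; at least one stereo element is drawn with a configuration in one of them and without one in the other: 2 of 4 stereo elements differ; a stereocentre at a saturated ring carbon is drawn R in compound 2 and S in compound 3; a stereocentre at a saturated ring carbon is drawn R in compound 2 and S in compound 3

Going by the values given here, no measured step bears directly on this change. The step from compound 1 to compound 2 concerns the exchange of a group, not the configuration of its stereocentres, so it gives no guide to the direction of the change from compound 2 to compound 3. Both measured compounds lie in the region of a full maximal response, and compound 3 retains the same atoms and bonds as compound 2. Compound 3 is therefore expected to give 100%, between 75% and 120%, a step of a number 10 percentage points lower from compound 2 to compound 3 (within the scatter) that is estimated to stay within the scatter.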

Compound 3, largest response reached (Emax), in percent of the reference or control that the assay uses: 120%
Compound 3: the middle estimate sits 20 percentage points below what was measured; measured number inside the range.
By their numbers in this assay, from the lowest: compound 1; then compounds 2 and 3 (each within the scatter of the next).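

In this assay, reversing both ring stereocentres of the 2-fluorocyclopropyl group comes to a number 10 percentage points higher from compound 2 to compound 3 (within the scatter), so at this position the maximal response does not tell the two drawn forms of the group apart. Measured against the methyl group on the same carbonyl carbon, this second form also stands clear, with a number 26 percentage points higher from compound 1 to compound 3 (beyond the scatter), which shows that the gain seen earlier is not confined to a single drawn form of the 2-fluorocyclopropyl group. How firmly the pair can be read as a true change of configuration depends on how the two structures are drawn: the fact that one of compounds 2 and 3 is drawn with a defined configuration and the other without, at the place where they differ

The compounds shown leave open whether the fluorine or the cyclopropyl ring carries the gain over the methyl group, since a plain cyclopropyl, a 2-chlorocyclopropyl or a longer chain such as propyl on the same carbonyl carbon would be needed to separate the two. They also leave open whether the two forms of the 2-fluorocyclopropyl group differ at the concentration needed to reach this response, which a maximal response alone cannot show.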